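The compounds below may be only part of what the source reports. "The series", "measured", "known", "first", "only" and "open" are said of these compounds alone.

Measured compounds:
compound 1 `CCOC(=O)NC(=O)[C@@H]1C[C@H](C)CC[C@H]1C(C)C`, 26000 nM
compound 2 `COc1ccc(NC(=O)[C@@H]2C[C@H](C)CC[C@H]2C(C)C)cc1`, 12000 nM

Both numbers come from an assay on isolated protein for agonist activity at transient receptor potential cation channel subfamily M member 8 (Homo sapiens), read by fluorescence; on this read-out higher numbers stand for an effect only at larger amounts of compound and lower numbers for an effect already at smaller amounts. Compound 2 has the lower of the two numbers, and compound 1 stands above it by a gap beyond the usual scatter. Compound 3 `COc1ccc(NC(=O)[C@@H]2C[C@H](C)CC[C@H]2C(C)C)c(NC(=O)[C@@H](C)N)c1` is not yet measured; it differs from compound 2 by ((1-aminoethyl)carbonyl)amino in place of hydrogen on an aromatic carbon, placed on an aromatic carbon of a six-membered aromatic ring of carbon only, ortho to a large group and meta to a methoxy group. Among the compounds with values here, no measured pair shows such a change, so the expectation is uncertain; a moderate step upward, beyond the scatter, is expected, a 2.5-fold higher number from compound 2 to compound 3 (0.40 log units; beyond the scatter). Compound 3 is therefore estimated at 30000 nM, within 8000 nM to 120000 nM.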

Compound 3, half-maximal effective concentration: 3000 nM
The estimate for compound 3 lay 10-fold (1.00 log units) above the measured number; the whole stated range lies above it.
By their numbers in this assay, from the lowest: compound 3; then compound 2; then compound 1.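

In this assay, putting ((1-aminoethyl)carbonyl)amino in place of hydrogen on this aromatic carbon, ortho to a large group and meta to a methoxy group, gives a 4.0-fold lower number from compound 2 to compound 3 (0.60 log units; beyond the scatter). Until now this carbon had carried only hydrogen, and this first substituent shows that it can hold a sizeable group while the number still falls. Nothing measured here bears on the reason for the drop.

The compounds shown leave open whether a plain amine on this carbon, or a longer chain ending in an amine, would do the same. They also leave open whether the mirror-image arrangement at the group's stereocentre would matter.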